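From pyrrolidin-1-yl to 4-methylpiperazin-1-yl on the side chain

The source may hold more compounds than are shown below. What is called first, only, known or untested is meant among the compounds shown, and "the series" means these compounds.

In a functional assay on MCF7 cells (Homo sapiens) for inhibition, read by MTT assay, with a stated time of 72 h (on this read-out higher numbers stand for weaker inhibition and lower numbers for stronger inhibition), compound 1 (`CCN(CC)CC(O)Cn1cc(CC(=O)O)c2ccccc21`) gives 3160 nM and compound 2 (`O=C(O)Cc1cn(CC(O)CN2CCCC2)c2ccccc12`) gives 1150 nM, the lower of the two numbers. Compound 3 (`CN1CCN(CC(O)Cn2cc(CC(=O)O)c3ccccc32)CC1`) has 4-methylpiperazin-1-yl in place of pyrrolidin-1-yl on a saturated chain carbon, two bonds along the chain from an oxygen on a saturated carbon. Among the compounds with values here, the only measured change at this place is a 2.7-fold lower number from compound 1 to compound 2 (0.44 log units; beyond the scatter), a modest step, and it involves no such ring. A similar or smaller move back towards a higher number is therefore expected, giving an estimated 1.7-fold higher number from compound 2 to compound 3 (0.24 log units; within the scatter). Compound 3 is expected at 2000 nM, within an estimated range of 700 nM to 5500 nM.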

Compound 3, half-maximal inhibitory concentration: 2440 nM
Beside the measured number, compound 3's estimate is 1.2-fold (0.09 log units) below it, and the stated range covers the measured number.
By their numbers in this assay, from the lowest: compound 2; then compounds 3 and 1 (each within the scatter of the next).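

In this assay replacing pyrrolidin-1-yl with 4-methylpiperazin-1-yl gives a 2.1-fold higher number from compound 2 to compound 3 (0.33 log units; beyond the scatter) and so does not keep the lower number of compound 2. Set against diethylamino, the same group gives a 1.3-fold lower number from compound 1 to compound 3 (0.11 log units; within the scatter) and leaves compound 1 and compound 3 indistinguishable, so among these three side chains only pyrrolidin-1-yl stands apart. Nothing available accounts for these steps. Still open, from the compounds shown here alone, is where morpholin-4-yl or piperidin-1-yl would fall at this place, and how the number would respond if the carboxylic acid on the shared core became a primary amide.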